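Trifluoromethylphenyl carbamate measured against its chloro-fluorophenyl forerunner

A few compounds are considered here, and "the series" means these few. Any claim that something is new, unique, unknown or untested is made for them only; others in the source may bear on it.

Measured in a functional assay on PANC-1 cells (Homo sapiens) for inhibition, read by MTT assay, with a stated time of 24 h, tested at 10 uM; a higher number here means more inhibition at the concentration tested (going by the name of the read-out), a lower number less inhibition:
compound 1, `CC(C)=CCC1Cc2c(OC(=O)Nc3ccc(F)cc3F)cc(=O)n(CCCO)c2CC1(C)C`, gives 69.7%
compound 2, `CC(C)=CCC1Cc2c(OC(=O)Nc3ccc(F)c(Cl)c3)cc(=O)n(CCCO)c2CC1(C)C`, gives 79.8%

Among the measured compounds shown here, compound 2 stands highest of the two numbers; its nearest neighbour is compound 1, and the one measured step, a number 10.1 percentage points higher from compound 1 to compound 2 (beyond the scatter), lies beyond the scatter. That step swaps one substituted phenyl for another on the amide-type nitrogen of the carbamate, the same place that is changed again in compound 3, `CC(C)=CCC1Cc2c(OC(=O)Nc3cccc(C(F)(F)F)c3)cc(=O)n(CCCO)c2CC1(C)C`, where the difference from compound 2 is 3-(trifluoromethyl)phenyl in place of 3-chloro-4-fluorophenyl on an amide-type nitrogen.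

For the measured compounds named here, only that single step bears on the new change, and it bears loosely: it speaks of a different pair of phenyl substituents, and nothing measured shows how a trifluoromethyl on the ring behaves. On these data alone, a step of about the size seen from compound 1 to compound 2, in either direction, or no step beyond the scatter, all remain open. Compound 3 is therefore expected to give 74% in this assay, within a range of 58% to 88%. That estimate means an expected step of a number 5.8 percentage points lower from compound 2 to compound 3 (within the scatter).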

Compound 3, a percentage reported as inhibition, at one concentration (the size of the read-out at that concentration, not a potency): 54.3%
The estimate for compound 3 lay 19.7 percentage points above the measured number, outside the stated range (below it).
By their numbers in this assay, from the lowest: compound 3; then compound 1; then compound 2.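

In this assay, the group on the amide-type nitrogen can lower the read-out as well as raise it: 3-(trifluoromethyl)phenyl in place of 3-chloro-4-fluorophenyl gives a number 25.5 percentage points lower from compound 2 to compound 3 (beyond the scatter), and in place of 2,4-difluorophenyl it gives a number 15.4 percentage points lower from compound 1 to compound 3 (beyond the scatter), both with the rest of the molecule unchanged. Compound 3 therefore stands lowest of the three, and among these compounds both rings carrying a chlorine or fluorine directly give more inhibition than the ring carrying trifluoromethyl, with no compound here against that order. Nothing given here accounts for this order.

On these data alone, whether a phenyl ring bearing a nitrile, a methoxy group or no substituent at all would stand nearer compound 2 or compound 3 remains open, so three aryl groups do not yet establish a trend at this position. Also open, as far as these compounds go, is whether these steps would keep their direction and size with another group elsewhere on the shared core, or at other concentrations, since each number describes inhibition at a single tested concentration and is not a potency.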